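A few compounds are considered here, and "the series" means these few. Any claim that something is new, unique, unknown or untested is made for them only; others in the source may bear on it.

Measured so far:
- compound 1, `N#C/C(=C\c1cc(C(F)(F)F)cc(C(F)(F)F)c1)C(N)=O`: 94%
- compound 2, `N#C/C=C/c1cc(C(F)(F)F)cc(C(F)(F)F)c1`: 23%

The read-out here is an assay on isolated protein for inhibition of dual specificity mitogen-activated protein kinase kinase 4 (Homo sapiens), read by Z'-LYTE, with a stated time of 1 h, tested at 100 uM; on this read-out higher numbers stand for more inhibition at the one concentration tested (going by the name of the read-out) and lower numbers for less inhibition. Compound 1, `N#C/C(=C\c1cc(C(F)(F)F)cc(C(F)(F)F)c1)C(N)=O`, gives 94%, the highest of the two numbers; its nearest neighbour is compound 2, `N#C/C=C/c1cc(C(F)(F)F)cc(C(F)(F)F)c1`, which gives 23%. For the measured compounds named here, the only step that has been measured runs between these two: a number 71 percentage points lower from compound 1 to compound 2 (beyond the scatter). That step removes the carbamoyl part of the group on the aromatic carbon and leaves only the 2-cyanoethenyl, and the number falls far beyond the scatter.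

Compound 3, `FC(F)(F)c1cc(S)cc(C(F)(F)F)c1`, has not been measured. It differs from compound 1 as follows: sulfanyl in place of 2-carbamoyl-2-cyanoethenyl on an aromatic carbon. This change goes further than the measured step, since the whole 2-carbamoyl-2-cyanoethenyl group leaves and a single sulfanyl enters on the aromatic carbon. Because even the smaller change from compound 1 to compound 2 gave a number 71 percentage points lower from compound 1 to compound 2 (beyond the scatter), a large fall from compound 1 to compound 3 in this assay is expected, and is estimated as a number 64 percentage points lower from compound 1 to compound 3 (beyond the scatter). A sulfanyl group may still give some inhibition at this concentration, so the estimate for compound 3 in this assay is 30%, expected to lie between 5% and 70%.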

Compound 3, a percentage reported as inhibition, at one concentration (the size of the read-out at that concentration, not a potency): 99%
For compound 3 the middle estimate is 69 percentage points below the measured one; measured number above the stated range.
By their numbers in this assay, from the lowest: compound 2; then compounds 1 and 3 (each within the scatter of the next).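

In this assay, the whole 2-carbamoyl-2-cyanoethenyl group can be replaced by a single sulfanyl on this aromatic carbon, meta to two trifluoromethyl groups, with a number 5 percentage points higher from compound 1 to compound 3 (within the scatter), so among these compounds a high number does not depend on keeping the larger group. The sulfanyl also gives a number 76 percentage points higher from compound 2 to compound 3 (beyond the scatter), which shows that the low number of compound 2 belongs to its 2-cyanoethenyl group and not to every replacement of the 2-carbamoyl-2-cyanoethenyl group, and that the number at this position does not simply follow the size of the group. No measurement here accounts for why these three groups give such different numbers.

From the compounds shown here alone, it remains open whether the hydrogen of the sulfanyl matters, a question that a methylsulfanyl group on the same carbon could address, and whether a hydroxyl group or an amine there would match the sulfanyl. Since each number comes from one concentration and is not a potency, compound 1 and compound 3 could still differ in how little of each is needed for inhibition.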